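This account rests on a few compounds, and the source may have more. Where it says the series, first, only, none or still open, it means among the compounds named here.

Measured so far in a functional assay on NCI-H23 cells (Homo sapiens) for inhibition, read by sulforhodamine B assay, with a stated time of 48 h; a lower number here means a stronger inhibitor of growth, a higher number a weaker inhibitor of growth:

Compound 1, `O=C(Nc1cccc(-n2cc(-c3ccncc3)c(-c3ccc(Cl)c(O)c3)n2)c1)Nc1cccc(C(F)(F)F)c1`: > 32500 nM
Compound 2, `O=C(Nc1cccc(-n2cc(-c3ccncc3)c(-c3ccc(Cl)c(O)c3)n2)c1)Nc1ccc(Cl)c(Cl)c1`: 29100 nM
Compound 3, `COc1cc(-c2nn(-c3cccc(NC(=O)Nc4ccc(Cl)c(C(F)(F)F)c4)c3)cc2-c2ccncc2)ccc1Cl`: 8030 nM

Compound 1 gives a value that is a limit of this assay rather than a number, as recorded in the limit of > 32500 nM in this assay, at which 1 of the 3 values shown sits. Among the two numbers available, compound 3 stands lowest, with compound 2 as the nearest number above it. For the measured compounds named here, the only step between two measured compounds that differ in a single place is an at least 1.1-fold lower number from compound 1 to compound 2 (0.04 log units; that floor lies within the scatter), which concerns the aryl group on the urea nitrogen and not the part of the molecule that changes next.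

Compound 4, `O=C(Nc1cccc(-n2cc(-c3ccncc3)c(-c3ccc(Cl)c(O)c3)n2)c1)Nc1ccc(Cl)c(C(F)(F)F)c1`, is not yet measured in this assay. It differs from compound 3 by hydrogen in place of methyl on an oxygen on an aromatic ring. Going by the values given here, no measured step touches this oxygen, so nothing in the data says how large the change will be or in which direction. What the data do show is that compound 1 and compound 2, which both carry the hydroxy group, sit high in this assay, while compound 3 with the methoxy group gives the lowest number; whether this comes from the oxygen substituent or from the urea aryl group cannot be separated here.

Compound 4 is therefore expected to give about 16000 nM, estimated between 5000 nM and 32500 nM, an expected step of a 2.0-fold higher number from compound 3 to compound 4 (0.30 log units; within the scatter).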

Compound 4, concentration for total growth inhibition: 3330 nM
Compound 4: middle estimate off by 4.8-fold (0.68 log units), on the high side, and the stated range ends above it.
By their numbers in this assay, from the lowest: compound 4; then compound 3; then compound 2. At a limit, above all of these: compound 1.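

In this assay, for the compounds shown here, hydrogen in place of methyl on the oxygen gives a 2.4-fold lower number from compound 3 to compound 4 (0.38 log units; beyond the scatter), so with the aryl group on the urea held fixed, going from methoxy to hydroxy lowers the number, a separation the earlier compounds could not make. With the hydroxy group held fixed, that aryl group also counts: trifluoromethyl in place of chloro on an aromatic carbon gives an 8.7-fold lower number from compound 2 to compound 4 (0.94 log units; beyond the scatter), and chloro in place of hydrogen on an aromatic carbon gives an at least 9.7-fold lower number from compound 1 to compound 4 (0.98 log units; beyond the scatter), so the high numbers among the hydroxy compounds go with the urea aryl group and not with the hydroxy group itself. Compound 1 stands at a limit of the assay and not at a number: the limit of > 32500 nM in this assay, at which 1 of the 4 values shown sits.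

Going by these compounds, the comparison of hydroxy with methoxy rests on a single pair, so whether it holds with other aryl groups on the urea remains open. Also open, on these data alone, is how this position would respond to an ethyl group on the oxygen, or to an amine in place of the hydroxy group.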